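Acetoxy-linked chloropurines on L1210 cells: iodo for amino

This account rests on a few compounds, and the source may have more. Where it says the series, first, only, none or still open, it means among the compounds named here.

Measured so far:
compound 1 `CC(=O)OC(C)n1cnc2c(Cl)nc(N)nc21` — > 500000 nM
compound 2 `CC(=O)OCCOn1cnc2c(Cl)nc(N)nc21` — > 500000 nM

In a functional assay on L1210 cells (Mus musculus) for inhibition (on this read-out lower numbers stand for stronger inhibition and higher numbers for weaker inhibition), compound 1 gives > 500000 nM, which is a limit of the assay and not a number. Compound 2 `CC(=O)OCCOn1cnc2c(Cl)nc(N)nc21` likewise sits at a limit, > 500000 nM. Compound 1 therefore stands at the point described by the limit of > 500000 nM in this assay, at which 2 of the 2 values shown sit, and no ordering between compound 1 and compound 2 can be drawn from what has been recorded.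

Compound 3 `CC(=O)OC(C)n1cnc2c(Cl)nc(I)nc21` is not yet measured. It differs from compound 1 by iodo in place of amino on an aromatic carbon, in words iodo in place of amino on an aromatic carbon. Among the compounds with values here, no step between measured compounds is known for this series, so the size of this change in this assay cannot be read from any measured pair. With both recorded values at a limit, the step of a number no higher from compound 1 to compound 3 (the limit leaves the size open) is expected to stay within the scatter of that limit. Compound 3 is estimated at 500000 nM, with a range from 100000 nM to 2000000 nM, most likely reported again only as a limit.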

Compound 3, half-maximal inhibitory concentration: 13000 nM
The estimate for compound 3 lay 38-fold (1.59 log units) above the measured number, outside the stated range (below it).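

In this assay, the aromatic carbon between two ring nitrogen atoms proves to be a position that matters: iodo in place of amino gives an at least 38-fold lower number from compound 1 to compound 3 (1.58 log units; beyond the scatter). Within the data shown here, compound 3 gives 13000 nM, the first actual number, so the shared core with its chloro group and the side chain of compound 1 does not by itself keep a compound out of the measurable range. The value of compound 1 is only a limit, so the step has a bound and no exact size: the limit of > 500000 nM in this assay, at which 2 of the 3 values shown sit.

Whether the change in read-out comes from iodo itself or simply from the loss of amino stays open, as bromo or plain hydrogen on this carbon is not among the compounds shown. Also open, from the compounds shown here alone, is whether iodo would have a similar effect with the side chain of compound 2.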